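Shortening the Chain on the Amino Side of the Core

The source may report more compounds than this note shows. Statements on the series, on what has been measured and on what is new or still open speak of the compounds shown alone.

Compound 2 `CCCCCCCCNc1cnc(C(=O)NCc2ccccc2)cn1` was examined in an ADME assay on MDCK cells (Canis lupus familiaris) for cytotoxicity, read by microscopy, with a stated time of 6 days; on this read-out higher numbers stand for lower toxicity in this test and lower numbers for higher toxicity in this test. In this assay compound 2 gives >= 20000 nM, which is a limit rather than a measured number. Its nearest measured relative is compound 1 `CCCCCCNc1cnc(C(=O)NCc2ccccc2)cn1`. In this assay compound 1 gives > 100000 nM, again a limit. The step that the two limits leave unreadable from compound 1 to compound 2 therefore cannot be read, as the two values sit at the limit of > 100000 nM in this assay, at which 1 of the 2 values shown sits, and (the limit of >= 20000 nM in this assay, at which 1 of the 2 values shown sits).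

The unmeasured compound 3 `CCCCCNc1cnc(C(=O)NCc2ccccc2)cn1` differs from compound 2 by hydrogen in place of propyl on a saturated chain carbon, five bonds along the chain from a nitrogen on an aromatic ring: a propyl group leaves and a hydrogen enters. Within the data shown here, the only measured comparison that bears on this kind of change is the one from compound 1 to compound 2, and its size is not readable, so no direction can be taken from it. Since neither measured compound yields a number in this assay, compound 3 is expected to behave alike. Compound 3 is estimated to give 100000 nM, within the range 20000 nM to 300000 nM, most probably again as a limit. The step that the limit leaves unreadable from compound 2 to compound 3 is expected to be no larger than the scatter.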

Compound 3, minimum cytotoxic concentration: > 100000 nM
Compound 3 was reported as a limit; the forecaster's own chance of this, stated with the estimate: 85%; the middle value lies on the limit itself.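

In this assay compound 1, compound 2 and compound 3 all stand at limits, so none of the steps among these three compounds can be read: the limit of > 100000 nM in this assay, at which 2 of the 3 values shown sit.

The compounds shown leave open where the minimum cytotoxic concentration of each compound actually lies, and whether the length of the chain on the amino side changes it at all.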